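The compounds below may be only part of what the source reports. "The series", "measured", "known", "first", "only" and "open" are said of these compounds alone.

Compound 1 `Oc1nc(-c2ccccc2)ncc1-c1nn[nH]n1` is the simplest of the set. In a functional assay on the whole organism with Rattus norvegicus as the target (a higher number here means that more compound is needed for the effect, a lower number that less compound is needed), compound 1 gives 100 mg/kg. Compound 2 `COc1ccccc1-c1ncc(-c2nn[nH]n2)c(O)n1` carries methoxy in place of hydrogen on an aromatic carbon and in this assay compound 2 gives 0.1 mg/kg, a step of a 1000-fold lower number from compound 1 to compound 2 (3.00 log units; beyond the scatter). Compound 3 `CCCOc1ccccc1-c1ncc(-c2nn[nH]n2)c(O)n1` gives in this assay 0.04 mg/kg, with steps of a 2500-fold lower number from compound 1 to compound 3 (3.40 log units; beyond the scatter) and a 2.5-fold lower number from compound 2 to compound 3 (0.40 log units; beyond the scatter). The cores of compound 1 and compound 3 differ by propoxy in place of hydrogen on an aromatic carbon.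

Compound 4 `CCCOc1ccc(OC)cc1-c1ncc(-c2nn[nH]n2)c(O)n1` is not yet measured. It differs from compound 3 by methoxy in place of hydrogen on an aromatic carbon, the same kind of change that turned compound 1 into compound 2, but not the same: the earlier methoxy sat ortho to a large group, whereas the new one sits meta to a large group and para to a propoxy group. Next to a 1000-fold lower number from compound 1 to compound 2 (3.00 log units; beyond the scatter), only a small step is expected, no change at the digits printed from compound 3 to compound 4 (within the scatter). That rests on the differing place and on compound 3 already standing at 0.04 mg/kg. Compound 4 is estimated at 0.04 mg/kg, between 0.01 mg/kg and 0.15 mg/kg.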

Compound 4, dose for 50% inhibition: 0.03 mg/kg
Estimate against measurement, compound 4: 1.3-fold (0.12 log units) above; measured number inside the range.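

In this assay the new methoxy gives a 1.3-fold lower number from compound 3 to compound 4 (0.12 log units; within the scatter) and so adds nothing that can be told apart from the scatter. Set beside the earlier step, the same change clearly does not carry its size from one core to the other: the same change on two cores in this assay, a 1000-fold lower number (3.00 log units; beyond the scatter) from compound 1 to compound 2 and a 1.3-fold lower number (0.12 log units; within the scatter) from compound 3 to compound 4, 750-fold (2.88 log units) apart, beyond the scatter of two such steps. This does not show why, since the two methoxy groups sit in different places and compound 3 already carries propoxy, so the effects of core and place cannot be separated.

Going by these compounds, it remains open whether methoxy at this same place on the core of compound 1 would give a large step. Also open, on these data alone, is what a longer chain in place of the propoxy, or an amine in place of the new methoxy, would do to the dose needed.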